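From phenyl to pyridin-2-yl: notes on the series

The compounds below may be only part of what the source reports. "The series", "measured", "known", "first", "only" and "open" are said of these compounds alone.

In a functional assay on HCT-15 cells (Homo sapiens) for cytotoxicity, read by colorimetric assay and MTT assay (a lower number here means a stronger inhibitor, a higher number a weaker inhibitor), compound 1 (`COc1ccc(-c2cc3c(OC)cc(OC)cc3n(CC(=O)O)c2=O)cc1`) reads 10000 nM and compound 2 (`COc1ccc(-c2cc3c(OC)cc(OC)cc3n(C)/c2=N\Nc2ccccc2)cc1`) reads 10000 nM as well, so compound 2 stands level with compound 1 within the scatter. Compound 3 (`COc1ccc(-c2cc3c(OC)cc(OC)cc3n(C)/c2=N\Nc2ccccn2)cc1`) carries pyridin-2-yl in place of phenyl on an amine nitrogen and is still unmeasured. With compound 2 at 10000 nM as the only close reference, no step beyond the scatter is expected in this assay for this change. The estimated step is a 1.3-fold lower number from compound 2 to compound 3 (0.10 log units; within the scatter) at the middle of the range. For compound 3 the expected value is 8000 nM (estimated range 2500 nM to 12000 nM).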

Compound 3, half-maximal inhibitory concentration: 10000 nM
The estimate for compound 3 lay 1.3-fold (0.10 log units) below the measured number; low and high end bracket the measured number.
By their numbers in this assay, from the lowest: compounds 1, 2 and 3 (each within the scatter of the next).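

In this assay pyridin-2-yl in place of phenyl on an amine nitrogen brings no change at the digits printed from compound 2 to compound 3 (within the scatter). This is the first comparison in the series shown that differs in one place, and the hydrogen-bond acceptor entering with pyridin-2-yl leaves the printed number as it was. Nothing at hand offers an explanation for this result.

Open, on these data alone, is whether another group on this amine nitrogen, such as benzyl or pyridin-4-yl, would give a different number. The pair also leaves open how changes elsewhere on the shared core would read.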